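Two Cores, One Shared Swap, Tested on A549 Cells

The source may hold more compounds than are shown below. What is called first, only, known or untested is meant among the compounds shown, and "the series" means these compounds.

Compound 1 `CCOC(=O)c1cc(-c2ccc(Cl)cc2)nn1CC(O)COc1ccccc1[N+](=O)[O-]` was run in a functional assay on A549 cells (Homo sapiens) for inhibition, read by MTT assay, with a stated time of 48 h (a lower number here means a stronger inhibitor, a higher number a weaker inhibitor), where compound 1 gives 26000 nM. Compound 2 `CCOC(=O)c1cc(-c2ccc(Cl)cc2)nn1CC(O)COc1ccccc1OC` differs from it only by methoxy in place of nitro on an aromatic carbon, and in this assay compound 2 gives 32000 nM, the step being a 1.2-fold higher number from compound 1 to compound 2 (0.09 log units; within the scatter). Compound 3 `CCOC(=O)c1cc(-c2ccc(OC)cc2)nn1CC(O)COc1ccccc1[N+](=O)[O-]` stands on a second core, which differs from the core of compound 1 by methoxy in place of chloro on an aromatic carbon; in this assay compound 3 gives 45000 nM, a step of a 1.7-fold higher number from compound 1 to compound 3 (0.24 log units; within the scatter). All three numbers lie within the usual scatter of one another, so no order among them can be drawn.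

Compound 4 `CCOC(=O)c1cc(-c2ccc(OC)cc2)nn1CC(O)COc1ccccc1OC` has not yet been measured. It differs from compound 3 by methoxy in place of nitro on an aromatic carbon, which is the same change that leads from compound 1 to compound 2, now made on the other core. For the measured compounds named here, because the one measured instance of this change gave a 1.2-fold higher number from compound 1 to compound 2 (0.09 log units; within the scatter), a step of similarly small size is expected from compound 3 to compound 4, namely a 1.2-fold higher number from compound 3 to compound 4 (0.06 log units; within the scatter). On that basis compound 4 is estimated at 52000 nM, with a likely range from 28000 nM to 95000 nM. This expectation rests on a single measured pair and on steps that themselves sit inside the scatter, so it is held loosely.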

Compound 4, half-maximal inhibitory concentration: 68000 nM
Compound 4: middle estimate off by 1.3-fold (0.12 log units), on the low side; the measured number falls inside the stated range.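

Methoxy in place of nitro gives a 1.5-fold higher number from compound 3 to compound 4 (0.18 log units; within the scatter), and this step carries over from one core to the other without a difference that can be told apart from the earlier one: the same change on two cores in this assay, a 1.2-fold higher number (0.09 log units; within the scatter) from compound 1 to compound 2 and a 1.5-fold higher number (0.18 log units; within the scatter) from compound 3 to compound 4, 1.2-fold (0.09 log units) apart, within the scatter of two such steps. Methoxy in place of chloro gives a 2.1-fold higher number from compound 2 to compound 4 (0.33 log units; beyond the scatter), a modest step, and it likewise agrees with its earlier instance: the same change on two cores in this assay, a 1.7-fold higher number (0.24 log units; within the scatter) from compound 1 to compound 3 and a 2.1-fold higher number (0.33 log units; beyond the scatter) from compound 2 to compound 4, 1.2-fold (0.09 log units) apart, within the scatter of two such steps. Both changes thus carried over between the two cores in these four compounds, but the nitro-to-methoxy steps lie within the scatter, so they do not show that this swap moves the number on either core, and two cores cannot show that either change would carry over across the wider series.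

The compounds shown leave open whether these steps would hold with other groups on the same aromatic carbon, such as an amine or a carboxylic acid. They also leave open what a longer chain in place of the ethyl of the ester would do to the numbers.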